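This account rests on a few compounds, and the source may have more. Where it says the series, first, only, none or still open, it means among the compounds named here.

Working notes on the series in a functional assay on 786-0 cells (Homo sapiens) for inhibition, read by sulforhodamine B assay, with a stated time of 48 h; a lower number here means a stronger inhibitor of growth, a higher number a weaker inhibitor of growth: compound 1 `CCOC(=O)c1nn(-c2ccc(Cl)cc2)c(-c2ccc(C)cc2)c1CNC(C)(C)C` gives > 588000 nM; > 542000 nM (2 entries) in its two entries, both limits of the assay and not numbers. Compound 2 `CC(C)(C)NCc1c(C(=O)O)nn(-c2ccc(Cl)cc2)c1-c1ccccc1` gives > 652000 nM as its only entry, again a limit and not a number. Compound 2 therefore has no single value to stand on, and no ranking against compound 1 can be drawn. Compound 3 `Cc1ccc(-c2c(CNC(C)(C)C)c(C(=O)O)nn2-c2ccc(Cl)cc2)cc1` differs from compound 2 by methyl in place of hydrogen on an aromatic carbon, phenyl to 4-methylphenyl. For the measured compounds named here, no step between measured compounds is available in this assay to size this change, and no shift beyond the usual scatter is expected in either direction. The estimated a number no higher from compound 2 to compound 3 (the limit leaves the size open) is accordingly small. For compound 3 the estimate is 650000 nM with an expected range from 300000 nM to 1000000 nM and another limit as the likely report.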

Compound 3, concentration for 50% growth inhibition: > 629000 nM
Compound 3: no number, only a limit; the forecaster's own chance of this, stated with the estimate: 85%; the middle value does not contradict the limit.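

In this assay, for the compounds shown here, compound 3 gives > 629000 nM, a limit and not a number; compound 2 also has only a limit, so no step between compound 2 and compound 3 can be read. The compounds shown leave open whether methyl in place of hydrogen on an aromatic carbon shifts growth inhibition at all.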